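Chloro for nitro on a cytotoxicity read-out

The compounds below may be only part of what the source reports. "The series", "measured", "known", "first", "only" and "open" are said of these compounds alone.

Measured compounds:
compound 1 `N/C(=N/NC(CC(=O)c1ccc(-n2ccnc2)cc1)c1ccccc1[N+](=O)[O-])c1ccccn1`, 48000 nM
compound 2 `N/C(=N/NC(CC(=O)c1ccc(-n2ccnc2)cc1)c1ccccc1Cl)c1ccccn1`, 53200 nM
compound 3 `N/C(=N/NC(CC(=O)c1ccc(-n2ccnc2)cc1)c1ccc([N+](=O)[O-])cc1)c1ccccn1`, 23100 nM

Of the compounds shown here, three have been tested in an ADME assay on Vero cells (Chlorocebus sabaeus) for cytotoxicity, read by MTT assay, with a stated time of 72 h; a lower number here means that less compound is tolerated, a higher number that more compound is tolerated. Compound 1 gives 48000 nM, compound 2 gives 53200 nM and compound 3 gives 23100 nM. Compound 3 carries the lowest number of the three: the step of a 2.1-fold lower number from compound 1 to compound 3 (0.32 log units; beyond the scatter) and the step of a 2.3-fold lower number from compound 2 to compound 3 (0.36 log units; beyond the scatter) both lie beyond the scatter. Compound 1 and compound 3 share their atoms but join them differently; that difference is 4-nitrophenyl in place of 2-nitrophenyl on a saturated chain carbon bound to an amine nitrogen and a saturated chain carbon.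

The change from compound 1 to compound 2 is chloro in place of nitro on an aromatic carbon, and its step was a 1.1-fold higher number from compound 1 to compound 2 (0.04 log units; within the scatter), a step that lies within the scatter.

Compound 4 `N/C(=N/NC(CC(=O)c1ccc(-n2ccnc2)cc1)c1ccc(Cl)cc1)c1ccccn1` has not yet been measured in this assay. It differs from compound 3 by chloro in place of nitro on an aromatic carbon. Among the compounds with values here, this is the same kind of change as the one from compound 1 to compound 2, but not the same: in the first pair the place is ortho to a large group, in the second pair it is para to a large group.

On the evidence of compound 1 and compound 2, where the same kind of change gave a 1.1-fold higher number from compound 1 to compound 2 (0.04 log units; within the scatter), the step from compound 3 to compound 4 is expected to be small, a 1.2-fold higher number from compound 3 to compound 4 (0.07 log units; within the scatter). Compound 4 is therefore estimated at 27000 nM, with a range from 12000 nM to 55000 nM.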

Compound 4, half-maximal cytotoxic concentration: 78800 nM
Estimate against measurement, compound 4: 2.9-fold (0.47 log units) below; measured number above the stated range.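

In this assay, chloro in place of nitro cannot be carried from one core to another in this series as a step of fixed size: the same change on two cores in this assay, a 1.1-fold higher number (0.04 log units; within the scatter) from compound 1 to compound 2 and a 3.4-fold higher number (0.53 log units; beyond the scatter) from compound 3 to compound 4, 3.1-fold (0.49 log units) apart, beyond the scatter of two such steps. The larger step, a 3.4-fold higher number from compound 3 to compound 4 (0.53 log units; beyond the scatter), sets compound 3 apart rather than compound 4, for the other two new steps, a 1.5-fold higher number from compound 2 to compound 4 (0.17 log units; within the scatter) and a 1.6-fold higher number from compound 1 to compound 4 (0.22 log units; within the scatter), both stay within the scatter, so that compounds 1, 2 and 4 cannot be told apart here and only the 4-nitrophenyl compound stands lower. This shows that the place on the ring can matter to the size of the step, but it rests on one pair at each place and does not show why the pairs differ, nor that chloro for nitro raises the number as a general rule.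

Still open, going by these compounds, is how an amine or a carboxylic acid would read in the place of the nitro group on the same ring, and whether either would follow the nitro or the chloro compounds. Also open, on these data alone, is whether a methoxy group would give steps that differ between the 2-substituted and 4-substituted phenyl compounds in the same way.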